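Swapping methyl for 4-fluorophenyl on the sulfonyl sulfur

The source may report more compounds than this note shows. Statements on the series, on what has been measured and on what is new or still open speak of the compounds shown alone.

In a functional assay on SNU-638 cells (Homo sapiens) for antiproliferative activity, read by sulforhodamine B assay, with a stated time of 72 h (a higher number here means a weaker inhibitor, a lower number a stronger inhibitor), compound 2 `COc1ncc(-c2ccc3ncnc(NCCN(C)C)c3c2)cc1NS(C)(=O)=O` gives 410 nM and compound 1 `CCCCS(=O)(=O)Nc1cc(-c2ccc3ncnc(NCCN(C)C)c3c2)cnc1OC` gives 480 nM, so the two stand within the scatter of each other. Compound 3 `COc1ncc(-c2ccc3ncnc(NCCN(C)C)c3c2)cc1NS(=O)(=O)c1ccc(F)cc1` carries 4-fluorophenyl in place of methyl on a sulfonyl sulfur. Within the data shown here, the one measured step in this sulfonyl substituent, a 1.2-fold lower number from compound 1 to compound 2 (0.07 log units; within the scatter), involves a saturated chain only, and no measured compound carries a ring there. Nothing beyond the scatter is therefore expected in this assay, with an estimated 1.2-fold lower number from compound 2 to compound 3 (0.07 log units; within the scatter). The estimate for compound 3 is 350 nM, with an expected range of 120 nM to 1000 nM.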

Compound 3, half-maximal inhibitory concentration: 1210 nM
Compound 3: the middle estimate sits 3.5-fold (0.54 log units) below what was measured; measured number outside the range, above it.
By their numbers in this assay, from the lowest: compounds 2 and 1 (each within the scatter of the next); then compound 3.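

In this assay, a ring on the sulfonyl sulfur behaves differently from the saturated chains: 4-fluorophenyl in place of methyl gives a 3.0-fold higher number from compound 2 to compound 3 (0.47 log units; beyond the scatter), and 4-fluorophenyl in place of butyl gives a 2.5-fold higher number from compound 1 to compound 3 (0.40 log units; beyond the scatter). Both steps are modest but lie beyond the scatter, whereas methyl and butyl stay within the scatter of each other. Nothing at hand explains this rise. On these data alone, it remains open whether the rise belongs to the aromatic ring or to its fluorine. A plain phenyl, a cyclopropyl or a chain ending in an amine on the sulfonyl sulfur would help to separate these.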